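Sulfur substituent series: toward the 3-hydroxypropyl analogue

The source may report more compounds than this note shows. Statements on the series, on what has been measured and on what is new or still open speak of the compounds shown alone.

Three members of the series carry a changing group on a sulfur attached to the shared core. Compound 1 `CC(C)c1n[nH]c2c(NCc3ccc(-c4ccccn4)cc3)nc(SCCC(N)=O)nc12` gives 120 nM in a functional assay on HT cells (Homo sapiens) for antiproliferative activity, read by fluorescence, with a stated time of 72 h; on this read-out lower numbers stand for stronger inhibition of growth and higher numbers for weaker inhibition of growth. Compound 2 `CC(C)c1n[nH]c2c(NCc3ccc(-c4ccccn4)cc3)nc(SC3CCCCC3O)nc12` gives 636 nM, and compound 3 `CC(C)c1n[nH]c2c(NCc3ccc(-c4ccccn4)cc3)nc(S)nc12`, with hydrogen on that sulfur, gives 2760 nM. Compound 2 thus stands second highest of the three numbers, with a 5.3-fold higher number from compound 1 to compound 2 (0.72 log units; beyond the scatter) separating it from compound 1 and a 4.3-fold higher number from compound 2 to compound 3 (0.64 log units; beyond the scatter) separating it from compound 3. Compound 4 `CC(C)c1n[nH]c2c(NCc3ccc(-c4ccccn4)cc3)nc(SCCCO)nc12` is not yet measured; its change from compound 2 is 3-hydroxypropyl in place of 2-hydroxycyclohexyl on a sulfur.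

Going by the values given here, two measured steps bear on this. The step of a 4.3-fold higher number from compound 2 to compound 3 (0.64 log units; beyond the scatter) shows that removing the 2-hydroxycyclohexyl altogether costs potency, so a group on the sulfur is worth keeping. The step of a 5.3-fold higher number from compound 1 to compound 2 (0.72 log units; beyond the scatter) shows that the 2-carbamoylethyl chain gives a lower number than the 2-hydroxycyclohexyl. The 3-hydroxypropyl of compound 4 is likewise a chain with one hydrogen-bond donor and one hydrogen-bond acceptor, so a move toward the number of compound 1 is expected, though perhaps not the whole way. Compound 4 is therefore expected to show a 3.2-fold lower number from compound 2 to compound 4 (0.50 log units; beyond the scatter), a lower number beyond the scatter. The estimate for compound 4 is 200 nM, with a range from 80 nM to 550 nM.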

Compound 4, concentration for 50% growth inhibition: 109 nM
Compound 4: the middle estimate sits 1.8-fold (0.26 log units) above what was measured; low and high end bracket the measured number.
By their numbers in this assay, from the lowest: compounds 4 and 1 (each within the scatter of the next); then compound 2; then compound 3.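

In this assay the open chain and the ring-bearing group on the sulfur are clearly separated (a 5.8-fold lower number from compound 2 to compound 4 (0.77 log units; beyond the scatter)), even though the 3-hydroxypropyl and the 2-hydroxycyclohexyl have the same counts of hydrogen-bond donors and acceptors, so those counts alone do not set the number at this position. The terminal group of the chain can differ without a measurable consequence here (a 1.1-fold lower number from compound 1 to compound 4 (0.04 log units; within the scatter)), so hydroxymethyl and carbamoyl cannot be told apart at this chain position, while the gain over the free sulfur group is large (a 25-fold lower number from compound 3 to compound 4 (1.40 log units; beyond the scatter)). Nothing available accounts for these differences in terms of mechanism.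

The compounds shown leave open whether the chain end tolerates an amine or a carboxylic acid as well as it tolerates hydroxymethyl and carbamoyl, and whether a longer chain or a shorter one holds the same level. They also leave open whether the gap between compound 2 and compound 4 comes from the six-membered ring itself or from the hydroxyl placement on it, which an unsubstituted cyclohexyl or a 4-hydroxybutyl chain would help to separate.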